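Swapping an Ethyl Ketone for an Aryl Ketone

A few compounds are considered here, and "the series" means these few. Any claim that something is new, unique, unknown or untested is made for them only; others in the source may bear on it.

Measured so far:
Compound 1 `CCC(=O)c1ccc2c(c1)C(n1ccccc1=O)=CC(C)(C)O2` gives 6.63 in a functional assay (aorta) with Rattus norvegicus as the target; a higher number here means a more potent compound, by a factor of ten per unit of this negative logarithm, a lower number a less potent compound.
Compound 2 `CC1(C)C=C(n2ccccc2=O)c2cc(C(=O)c3cccs3)ccc2O1` gives 6.4 in this assay.

Of these two numbers, compound 1 stands at the top, yet the step of a number 0.23 log units lower from compound 1 to compound 2 (within the scatter) is within the scatter, so the two cannot be told apart. Compound 3 `CC1(C)C=C(n2ccccc2=O)c2cc(C(=O)c3ccccc3C(F)(F)F)ccc2O1` is not yet measured. Its difference from compound 1 is 2-(trifluoromethyl)phenyl in place of ethyl on a carbonyl carbon. Among the measured compounds shown here, the only step that bears on this change is a number 0.23 log units lower from compound 1 to compound 2 (within the scatter), where an aromatic ring also replaced ethyl on the carbonyl carbon without moving the number beyond the scatter. A step of similar size, not beyond the scatter, is therefore expected for compound 3: a number 0.13 log units lower from compound 1 to compound 3 (within the scatter). Compound 3 is estimated at 6.5, between 5.9 and 7.1.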

Compound 3, logarithm of the reciprocal of the active concentration, log(1/C): 6.76
For compound 3 the middle estimate is 0.26 log units below the measured one; the measured number falls inside the stated range.
By their numbers in this assay, from the lowest: compounds 2, 1 and 3 (each within the scatter of the next, the first and the last beyond it).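

A far larger group can sit on this carbonyl carbon: with 2-(trifluoromethyl)phenyl in place of ethyl, the numbers stay within the scatter (a number 0.13 log units higher from compound 1 to compound 3 (within the scatter)). The choice of aromatic ring can still matter, as 2-(trifluoromethyl)phenyl in place of thiophen-2-yl gives a modest step beyond the scatter (a number 0.36 log units higher from compound 2 to compound 3 (beyond the scatter)). Nothing available here explains that difference.

From the compounds shown here alone, whether the trifluoromethyl group itself contributes remains open, since plain phenyl is absent from this set. Also open, going by these compounds, is how an amine or a carboxylic acid would fare on this carbonyl carbon.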